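Phenoxy for tert-Butylphenyl: Permeability Outlook for Compound 4

This account rests on a few compounds, and the source may have more. Where it says the series, first, only, none or still open, it means among the compounds named here.

Of the compounds shown here, three built on a shared core have been measured in an ADME assay for permeability, using PAMPA, with a stated time of 30 min, at pH 7.4; on this read-out higher numbers stand for higher permeability and lower numbers for lower permeability. Compound 1 `COc1cccc(CNCCCNc2ccnc3cc(Oc4ccccc4)ccc23)c1O` gives 317 10^-6 cm/s. Compound 2 `COc1cccc(CNCCCNc2ccnc3cc(-c4ccc(C(C)(C)C)cc4)ccc23)c1O` gives 237 10^-6 cm/s, and compound 3 `CC(C)(C)c1ccc(-c2ccc3c(NCCCNCc4ccco4)ccnc3c2)cc1` gives 237 10^-6 cm/s. The difference between compound 2 and compound 1 is phenoxy in place of 4-(tert-butyl)phenyl on an aromatic carbon, and the measured step reads a 1.3-fold higher number from compound 2 to compound 1 (0.13 log units; within the scatter). The difference between compound 2 and compound 3 is furan-2-yl in place of 2-hydroxy-3-methoxyphenyl on a saturated chain carbon bound to an amine nitrogen, with a step of no change at the digits printed from compound 2 to compound 3 (within the scatter).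

Compound 4 `c1ccc(Oc2ccc3c(NCCCNCc4ccco4)ccnc3c2)cc1` has not yet been measured in this assay. Among the compounds with values here, it differs from compound 3 by phenoxy in place of 4-(tert-butyl)phenyl on an aromatic carbon, the same change, at the same place, as the one from compound 2 to compound 1. Because the earlier step reads a 1.3-fold higher number from compound 2 to compound 1 (0.13 log units; within the scatter), a step of similar size is expected, a 1.3-fold higher number from compound 3 to compound 4 (0.10 log units; within the scatter). Compound 4 is accordingly estimated at 300 10^-6 cm/s in this assay, with the estimate spanning from 180 10^-6 cm/s to 450 10^-6 cm/s.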

Compound 4, apparent permeability in the ADME assay: 317 10^-6 cm/s
Compound 4: the middle estimate sits 1.1-fold (0.02 log units) below what was measured; the range from low to high includes it.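

In the ADME assay compound 3 gives 237 10^-6 cm/s and compound 4 gives 317 10^-6 cm/s. In the ADME assay, phenoxy in place of 4-(tert-butyl)phenyl reads a 1.3-fold higher number from compound 3 to compound 4 (0.13 log units; within the scatter), and this step agrees with the one seen on the other core: the same change on two cores in the ADME assay, a 1.3-fold higher number (0.13 log units; within the scatter) from compound 2 to compound 1 and a 1.3-fold higher number (0.13 log units; within the scatter) from compound 3 to compound 4, 1.0-fold (0.00 log units) apart, within the scatter of two such steps. In the ADME assay, furan-2-yl in place of 2-hydroxy-3-methoxyphenyl reads no change at the digits printed from compound 1 to compound 4 (within the scatter), and this step likewise agrees with its earlier counterpart: the same change on two cores in the ADME assay, no change at the digits printed (within the scatter) from compound 2 to compound 3 and no change at the digits printed (within the scatter) from compound 1 to compound 4, 1.0-fold (0.00 log units) apart, within the scatter of two such steps. The four compounds therefore show that each change carried over between these two cores without a detectable difference, but since every step lies within the scatter, they do not show that either change shifts the read-out, or that a step of clear size would carry over in the same way. In a physicochemical assay for acid dissociation, compound 3 gives 9.47 and compound 4 gives 9.28. In the physicochemical assay, phenoxy in place of 4-(tert-butyl)phenyl reads a number 0.19 log units lower from compound 3 to compound 4 (within the scatter).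

The compounds shown leave open how the series would respond if an amine or a carboxylic acid stood on the aromatic carbon that holds phenoxy. They also leave open whether the same agreement between steps would hold with a longer chain in place of the present one.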